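This account rests on a few compounds, and the source may have more. Where it says the series, first, only, none or still open, it means among the compounds named here.

Of the compounds shown here, two that share one core have been measured in an ADME assay on A549 cells (Homo sapiens) for cytotoxicity, read by resazurin assay, with a stated time of 48 h; a higher number here means that more compound is tolerated, a lower number that less compound is tolerated. Compound 1 `CCN(CC)c1ccc(NC(=O)c2cc(Cl)ccc2O)c(Cl)c1` gives 55500 nM in this assay. Compound 2 `O=C(Nc1ccc(NCc2cc(C(F)(F)F)cc(C(F)(F)F)c2)cc1Cl)c1cc(Cl)ccc1O` gives 92800 nM in this assay. Compound 1 holds the lowest of these two numbers, but the two lie within the scatter of each other, so the data show no difference between them.

Compound 3 `O=C(Nc1ccc(NCc2cccc(Br)n2)cc1Cl)c1cc(Cl)ccc1O` has not been measured yet. It differs from compound 1 in one place: ((6-bromopyridin-2-yl)methyl)amino in place of diethylamino on an aromatic carbon. Among the compounds with values here, no measured pair shows what such a change does in this assay, so no step size is known from the data. At that place compound 3 resembles compound 2 more than it resembles compound 1, and compound 2 gives 92800 nM. The expected step is therefore a 1.3-fold higher number from compound 1 to compound 3 (0.10 log units; within the scatter), no larger than the scatter. Compound 3 is expected to give about 70000 nM, with a range from 30000 nM to 160000 nM.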

Compound 3, half-maximal cytotoxic concentration: 92300 nM
Estimate against measurement, compound 3: 1.3-fold (0.12 log units) below; the measured number falls inside the stated range.
By their numbers in this assay, from the lowest: compounds 1, 3 and 2 (each within the scatter of the next).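

In this assay, putting ((6-bromopyridin-2-yl)methyl)amino in place of diethylamino on this aromatic carbon gives a 1.7-fold higher number from compound 1 to compound 3 (0.22 log units; within the scatter), so the data show no difference between the two. Within the data shown here, this is the first measured step at this position, and it shows that a group bringing an aromatic ring, a bromine and a hydrogen-bond donor leaves the number within the scatter of the one for the plain dialkylamino group. Nothing measured here gives a reason for this outcome.

The compounds shown leave open whether the bromine plays any part, since no close relative carries a hydrogen or a chlorine in its place. They also leave open what a plain amino group or a carboxylic acid at this position would do in this assay.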